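The source may hold more compounds than are shown below. What is called first, only, known or untested is meant among the compounds shown, and "the series" means these compounds.

Measured so far:
compound 1, `O=C(/C=C/c1ccc2ccc(C(F)(F)F)cc2n1)c1ccncc1` — in an ADME assay on A549 cells (Homo sapiens) for cytotoxicity (a higher number here means a weaker inhibitor, a lower number a stronger inhibitor), compound 1 gives 15000 nM
compound 2, `O=C(/C=C/c1ccc2ccc(C(F)(F)F)cc2n1)c1ccccn1` — in this assay compound 2 gives 10200 nM

Going by the values given here, compound 2 stands at one end of this pair, but its only comparison is compound 1, and the step of a 1.5-fold lower number from compound 1 to compound 2 (0.17 log units; within the scatter) is within the scatter, so the two numbers cannot be told apart with confidence. The next compound is compound 3, `O=C(/C=C/c1ccc2ccc(C(F)(F)F)cc2n1)c1cccnc1`. It shares the whole core with compound 2 and differs only in the attached ring, pyridin-3-yl in place of pyridin-2-yl on a carbonyl carbon: pyridin-2-yl leaves and pyridin-3-yl enters on the carbonyl carbon, so the same atoms are joined differently.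

Among the compounds with values here, the one measured step that bears on this is the earlier shift of the ring nitrogen on that same carbonyl carbon, from pyridin-4-yl to pyridin-2-yl, which gave a 1.5-fold lower number from compound 1 to compound 2 (0.17 log units; within the scatter), a change inside the scatter. Moving the nitrogen once more is therefore expected to give no step beyond the scatter, roughly a 1.2-fold higher number from compound 2 to compound 3 (0.07 log units; within the scatter). Compound 3 is estimated at 12000 nM in this assay, with a likely range from 5000 nM to 30000 nM.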

Compound 3, half-maximal inhibitory concentration: 9800 nM
The estimate for compound 3 lay 1.2-fold (0.09 log units) above the measured number, within the range that was stated.
By their numbers in this assay, from the lowest: compounds 3, 2 and 1 (each within the scatter of the next).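

With pyridin-3-yl in place, all three pyridine rings that can sit on this carbonyl carbon can now be compared in this assay. Going by these compounds alone, the new compound gives a 1.0-fold lower number from compound 2 to compound 3 (0.02 log units; within the scatter) and also a 1.5-fold lower number from compound 1 to compound 3 (0.18 log units; within the scatter) so that, together with the earlier step, no pair among the three can be told apart. Among these compounds, then, exchanging pyridin-2-yl, pyridin-3-yl and pyridin-4-yl at this place leaves the number within the scatter, and no measurement is available here that would explain this.

Going by these compounds, what remains open is whether a different kind of group on this carbonyl carbon, such as a plain phenyl ring or a pyridine ring carrying an amine or a carboxylic acid, would produce a step beyond the scatter. On these data alone, it is also open whether these pyridine rings would remain indistinguishable if the trifluoromethyl group on the shared core were replaced by another group, such as a nitrile.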